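This account rests on a few compounds, and the source may have more. Where it says the series, first, only, none or still open, it means among the compounds named here.

Measured in a functional assay on DWD cells (Homo sapiens) for inhibition, read by sulforhodamine B assay; on this read-out lower numbers stand for stronger inhibition of growth and higher numbers for weaker inhibition of growth:
- compound 1 `FC(F)(F)Oc1ccc(-c2ccc(-c3ccc(-c4nc5ccccc5[nH]4)cc3)cc2)cc1` gives 100000 nM
- compound 2 `Oc1cccc2[nH]c(-c3ccc(-c4ccc(-c5ccccc5)cc4)cc3)nc12` gives 9680 nM
- compound 3 `Oc1cccc2[nH]c(-c3ccc(-c4ccc(-c5ccc(OC(F)(F)F)cc5)cc4)cc3)nc12` gives 3100 nM

Compound 3 has the lowest number of the three. Compound 4 `Oc1cccc2[nH]c(-c3ccc(-c4ccc(-c5cccc(Cl)c5)cc4)cc3)nc12` has 3-chlorophenyl in place of 4-(trifluoromethoxy)phenyl on an aromatic carbon. The hydroxy step a 32-fold lower number from compound 1 to compound 3 (1.51 log units; beyond the scatter) concerns a group that compound 4 keeps, so it offers little guidance here. The closer precedent is a 3.1-fold lower number from compound 2 to compound 3 (0.49 log units; beyond the scatter), since compound 4 loses the trifluoromethoxy group. Going by the values given here, no chlorine-bearing compound has been measured, so only a modest rise in the number is expected, with wide uncertainty. The expected step is a 1.5-fold higher number from compound 3 to compound 4 (0.16 log units; within the scatter). The estimate for compound 4 is 4500 nM, with an expected range of 1800 nM to 11000 nM.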

Compound 4, concentration for 50% growth inhibition: 2100 nM
Beside the measured number, compound 4's estimate is 2.1-fold (0.33 log units) above it; measured number inside the range.
By their numbers in this assay, from the lowest: compounds 4 and 3 (each within the scatter of the next); then compound 2; then compound 1.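

At this position, the swap of 4-(trifluoromethoxy)phenyl for 3-chlorophenyl gives no separable change in this assay (a 1.5-fold lower number from compound 3 to compound 4 (0.17 log units; within the scatter)), so a lower number than that of compound 2 no longer rests on trifluoromethoxy alone. Chloro in place of hydrogen also lowers the number (a 4.6-fold lower number from compound 2 to compound 4 (0.66 log units; beyond the scatter)), a step of modest size. No evidence is available to explain either result.

Still open, from the compounds shown here alone, is whether chloro and trifluoromethoxy would match when carried at the same ring position. Going by these compounds, the response to an amine or a carboxylic acid at this position also remains open.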